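The source may hold more compounds than are shown below. What is called first, only, known or untested is meant among the compounds shown, and "the series" means these compounds.

Three measured compounds define the series. Compound 1 `CC[C@@H]1C[C@H](CC)CN(CCCNC(=O)C2CCN(Cc3nc(-c4ccccc4C)oc3C)CC2)C1` gives 3470 nM in an ADME assay on Huh7.5.1 cells (Homo sapiens) for cytotoxicity, read by ATP content, with a stated time of 48 h; on this read-out higher numbers stand for lower toxicity in this test and lower numbers for higher toxicity in this test; compound 3 `CCCN(CCC)CCNC(=O)C1CCN(Cc2nc(-c3ccccc3C)oc2C)CC1` gives 30500 nM; compound 2 `Cc1oc(-c2ccc(F)cc2)nc1CN1CCC(C(=O)NCCCN2C[C@H](C)C[C@H](C)C2)CC1` gives 12800 nM, the second highest of the three numbers, between compound 3 and compound 1. Within the data shown here, the only single-point step measured, an 8.8-fold higher number from compound 1 to compound 3 (0.94 log units; beyond the scatter), concerns the amine end of the chain. Compound 4 `COc1cccc(Br)c1-c1nc(CN2CCC(C(=O)NCCCN3C[C@H](C)C[C@H](C)C3)CC2)c(C)o1` differs from compound 2 elsewhere: 2-bromo-6-methoxyphenyl in place of 4-fluorophenyl on an aromatic carbon. Among the measured compounds shown here, no measured step touches this aromatic carbon, so the step from compound 1 to compound 3 does not bear on it, and a step within the scatter is expected for a 1.1-fold lower number from compound 2 to compound 4 (0.03 log units; within the scatter). Compound 4 is therefore estimated at 12000 nM, expected to fall between 4500 nM and 32000 nM.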

Compound 4, half-maximal cytotoxic concentration: 14900 nM
Compound 4: the middle estimate sits 1.2-fold (0.09 log units) below what was measured; the measured number falls inside the stated range.
By their numbers in this assay, from the lowest: compound 1; then compounds 2 and 4 (each within the scatter of the next); then compound 3.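

At this aromatic carbon, next to the ring nitrogen and the ring oxygen, 2-bromo-6-methoxyphenyl and 4-fluorophenyl read alike in this assay, with a 1.2-fold higher number from compound 2 to compound 4 (0.07 log units; within the scatter) on the shared core. On this pair, the two additional heavy atoms and the hydrogen-bond acceptor of the entering group leave the number within the scatter, whereas the amine end gave an 8.8-fold higher number from compound 1 to compound 3 (0.94 log units; beyond the scatter) for its step. No available data explain this result.

Open, going by these compounds, is whether an amine or a carboxylic acid on the phenyl ring would shift the number beyond the scatter. Also open, on these data alone, is whether 2-bromo-6-methoxyphenyl reads the same alongside the dipropylamino end.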